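The compounds below may be only part of what the source reports. "The series", "measured", "known", "first", "only" and "open" are said of these compounds alone.

Measured in a functional assay on HeLa cells (Homo sapiens) for cytotoxicity, read by MTT assay, with a stated time of 48 h; on this read-out lower numbers stand for stronger inhibition and higher numbers for weaker inhibition:
- compound 1 `O=C(O)CN1C(=O)/C(=C/c2nc3ccccc3n2Cc2ccc(Br)cc2)SC1=S`: 12900 nM
- compound 2 `O=C(O)CN1C(=O)/C(=C/c2nc3ccccc3n2Cc2ccccc2F)SC1=S`: 640 nM
- compound 3 `O=C(O)CN1C(=O)/C(=C/c2nc3ccccc3n2Cc2ccc(F)cc2F)SC1=S`: 26100 nM

Compound 3 stands highest of the three, at 26100 nM. Compound 4 `O=C(O)CN1C(=O)/C(=C/c2nc3ccccc3n2Cc2ccc(F)c(F)c2)SC1=S` carries 3,4-difluorophenyl in place of 2,4-difluorophenyl on a saturated chain carbon bound to an aromatic nitrogen. Within the data shown here, no measured step makes this exact change. The closest evidence is a 41-fold higher number from compound 2 to compound 3 (1.61 log units; beyond the scatter), which is large, with fluoro in place of hydrogen on an aromatic carbon. Beside it stand a 2.0-fold higher number from compound 1 to compound 3 (0.31 log units; beyond the scatter), which is modest, and a 20-fold lower number from compound 1 to compound 2 (1.30 log units; beyond the scatter), which is large. These steps show that this group can move the number strongly, so a moderate move to a lower number is expected in this assay, though with wide uncertainty. The expected step is a 2.9-fold lower number from compound 3 to compound 4 (0.46 log units; beyond the scatter). For compound 4 the estimate is 9000 nM, with an expected range of 1800 nM to 35000 nM.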

Compound 4, half-maximal inhibitory concentration: 16000 nM
Compound 4: middle estimate off by 1.8-fold (0.25 log units), on the low side; measured number inside the range.
By their numbers in this assay, from the lowest: compound 2; then compounds 1, 4 and 3 (each within the scatter of the next, the first and the last beyond it).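

In this assay, the move from 2,4-difluorophenyl to 3,4-difluorophenyl on a saturated chain carbon bound to an aromatic nitrogen gives a 1.6-fold lower number from compound 3 to compound 4 (0.21 log units; within the scatter) and so does not separate these two groups, while a 1.2-fold higher number from compound 1 to compound 4 (0.09 log units; within the scatter) puts 3,4-difluorophenyl level with 4-bromophenyl as well. Among the compounds shown, only the 2-fluorophenyl of compound 2 stands apart, with a 25-fold higher number from compound 2 to compound 4 (1.40 log units; beyond the scatter) as its step to the new compound. No measurement shown here accounts for this gap. As far as these compounds go, it remains open whether plain phenyl or a methoxyphenyl group at this place would side with compound 2 or with the other three.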